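A few compounds are considered here, and "the series" means these few. Any claim that something is new, unique, unknown or untested is made for them only; others in the source may bear on it.

The measured compounds, in a functional assay on ASPC1 cells (Homo sapiens) for antiproliferative activity, read by sulforhodamine B assay, with a stated time of 48 h; a lower number here means a stronger inhibitor, a higher number a weaker inhibitor:

Compound 1, `O=C(CCCCCCN1C(=O)/C(=N\O)c2cc(F)ccc21)NO`, gives 1720 nM.
Compound 2, `O=C(CCCCCCN1C(=O)/C(=N\O)c2cc(Cl)ccc21)NO`, gives 1860 nM.
Compound 3, `CO/N=C1/C(=O)N(CCCCCCC(=O)NO)c2ccc(F)cc21`, gives 970 nM.

Compounds 1 and 2 share a core and differ in one place: chloro in place of fluoro on an aromatic carbon. In this assay this change gave a 1.1-fold higher number from compound 1 to compound 2 (0.03 log units; within the scatter), so the two values of compound 1 and compound 2 are indistinguishable within the usual repeat variation of the assay. Compound 3 carries a different core; how it differs from the core of compound 1 is not broken down here, and its value beside those of compound 1 and compound 2 falls within the scatter of both.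

Compound 4, `CO/N=C1/C(=O)N(CCCCCCC(=O)NO)c2ccc(Cl)cc21`, has not yet been measured. It stands to compound 3 exactly as compound 2 stands to compound 1: chloro in place of fluoro on an aromatic carbon, at a place described in the same words for both pairs. For the measured compounds named here, the only guide to its behaviour is the step from compound 1 to compound 2, which was a 1.1-fold higher number from compound 1 to compound 2 (0.03 log units; within the scatter). On that basis a step of similar size is expected, a 1.1-fold higher number from compound 3 to compound 4 (0.03 log units; within the scatter), from compound 3 to compound 4. Compound 4 is therefore estimated to give 1050 nM in this assay, with a likely range from 550 nM to 2100 nM.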

Compound 4, half-maximal inhibitory concentration: 490 nM
The estimate for compound 4 lay 2.1-fold (0.33 log units) above the measured number; measured number outside the range, below it.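

In this assay, chloro in place of fluoro on an aromatic carbon gave a 2.0-fold lower number from compound 3 to compound 4 (0.30 log units; within the scatter), a step that, like the earlier one, stays within the usual scatter. Set side by side, the two steps cannot be told apart: the same change on two cores in this assay, a 1.1-fold higher number (0.03 log units; within the scatter) from compound 1 to compound 2 and a 2.0-fold lower number (0.30 log units; within the scatter) from compound 3 to compound 4, 2.1-fold (0.33 log units) apart, within the scatter of two such steps. The four compounds therefore give no sign that this change behaves differently on the two cores, and in neither pair does it separate the two values beyond repeat variation; this does not prove that the change carries over unaltered, as two steps are a slim basis and a small dependence on the core could lie hidden within the scatter.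

The compounds shown leave open what other groups on the same aromatic carbon, such as bromo, methyl or methoxy, would give on either core. For the compounds shown here, they also leave open whether the fluoro and chloro pairs would stay this close with a longer chain in place of the one all four compounds carry.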